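A few compounds are considered here, and "the series" means these few. Any claim that something is new, unique, unknown or untested is made for them only; others in the source may bear on it.

Two compounds of this series carry numbers in an assay for inhibition of beta-glucuronidase (Bos taurus), read by spectrophotometry, with a stated time of 30 min; on this read-out higher numbers stand for weaker inhibition and lower numbers for stronger inhibition. Compound 1 `O=[N+]([O-])c1ccc(S(=O)(=O)Nc2cnc3ccccc3c2)cc1` gives 31600 nM. Compound 2 `O=[N+]([O-])c1cccc(S(=O)(=O)Nc2cnc3ccccc3c2)c1` gives 46200 nM, the higher of the two numbers, a gap to compound 1 that lies within the scatter. Compound 3 `O=S(=O)(Nc1cnc2ccccc2c1)c1ccccc1` differs from compound 2 by hydrogen in place of nitro on an aromatic carbon. For the measured compounds named here, no measured pair shows this change. Compounds 1 and 2 give similar numbers with the nitro in either place, so for compound 3 the step is expected to be a 1.4-fold higher number from compound 2 to compound 3 (0.15 log units; within the scatter), a modest rise near the edge of the scatter. Compound 3 is therefore estimated at 65000 nM, within 22000 nM to 200000 nM.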

Compound 3, half-maximal inhibitory concentration: 53400 nM
Compound 3: the middle estimate sits 1.2-fold (0.09 log units) above what was measured; the measured number falls inside the stated range.
By their numbers in this assay, from the lowest: compounds 1, 2 and 3 (each within the scatter of the next).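

In this assay hydrogen in place of nitro on an aromatic carbon leaves the number within the scatter from either nitro compound (a 1.2-fold higher number from compound 2 to compound 3 (0.06 log units; within the scatter); a 1.7-fold higher number from compound 1 to compound 3 (0.23 log units; within the scatter)). The nitro is thus not needed to hold the number at this level, and neither nitro placement stands apart from the compound without it. No measured evidence bears on this result.

On these data alone, whether any group on this ring moves the number beyond the scatter stays open. An amine, a carboxylic acid or a methoxy group would each need its own value in this series.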